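The compounds below may be only part of what the source reports. "The series", "measured", "known", "first", "only" and "open" are said of these compounds alone.

Three small fluorinated alcohols have been measured in a physicochemical assay for lipophilicity, read by NMR; a higher number here means a more lipophilic compound, a lower number a more polar compound. Compound 2, `OCCCC(F)F`, gives 0.29. Compound 1, `CC(O)CCC(F)F`, gives 0.64. Compound 3, `CCC(F)(F)CO`, gives 0.67; its value and that of compound 1 lie within the scatter of each other. Compound 3 and compound 2 are built from the same atoms joined differently, and the difference between the two cores is not broken down here.

From compound 2 to compound 1 the change is methyl in place of hydrogen on a saturated chain carbon bound to an oxygen on a saturated carbon and a saturated chain carbon, and it made a number 0.35 log units higher from compound 2 to compound 1 (beyond the scatter).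

Compound 4, `CCC(F)(F)C(C)O`, is not yet measured. It differs from compound 3 by methyl in place of hydrogen on a saturated chain carbon bound to an oxygen on a saturated carbon and a saturated chain carbon, the same change, at the same kind of place, as that from compound 2 to compound 1. Since that single earlier example moved the value by a number 0.35 log units higher from compound 2 to compound 1 (beyond the scatter), a step of about a number 0.33 log units higher from compound 3 to compound 4 (beyond the scatter) is expected here, with the caveat that it rests on one pair only. Compound 4 is therefore estimated at 1, most likely between 0.75 and 1.3.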

Compound 4, partition coefficient: 1.04
Estimate against measurement, compound 4: 0.04 log units below, within the range that was stated.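

In this assay, methyl in place of hydrogen on a saturated chain carbon bound to an oxygen on a saturated carbon and a saturated chain carbon gave a number 0.37 log units higher from compound 3 to compound 4 (beyond the scatter), much like the earlier a number 0.35 log units higher from compound 2 to compound 1 (beyond the scatter). On these two cores, then, the change carried over from one to the other in both direction and approximate size, and a step measured on one core served as a fair guide to the other. This rests on two pairs of small fluorinated alcohols, so it does not establish a general rule for other cores, and nothing measured here explains why the step has this size.

The compounds shown leave open whether a step of this size would appear on a core where an amine or a carboxylic acid takes the place of the alcohol. They also leave open what a longer chain would do in place of the methyl, on either core.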